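The source may report more compounds than this note shows. Statements on the series, on what has been measured and on what is new or still open speak of the compounds shown alone.

Compound 1 `O=C(CCCCCCc1ccccc1)c1ncc(-c2ccco2)s1` carries a furan-2-yl group on its core. In an assay on HEK-293T cells for inhibition of diacylglycerol lipase-alpha (Homo sapiens), read by colorimetric assay (on this read-out higher numbers stand for weaker inhibition and lower numbers for stronger inhibition), compound 1 gives > 10000 nM, which is a limit of the assay and not a number. Compound 2 `O=C(CCCCCCc1ccccc1)c1ncc(-c2cccs2)s1` differs from compound 1 by thiophen-2-yl in place of furan-2-yl on an aromatic carbon. In this assay compound 2 gives > 10000 nM, again a limit. The step that the two limits leave unreadable from compound 1 to compound 2 therefore cannot be sized, since both ends sit at the limit of > 10000 nM in this assay, at which 3 of the 3 values shown sit. Compound 3 `O=C(CCCCCCc1ccccc1)c1nnc(-c2ccco2)s1` is built on a different core; the difference between the two cores is not broken down here. In this assay compound 3 gives > 10000 nM, once more a limit. Compound 4 `O=C(CCCCCCc1ccccc1)c1nnc(-c2cccs2)s1` has not yet been measured in this assay. It differs from compound 3 by thiophen-2-yl in place of furan-2-yl on an aromatic carbon. Within the data shown here, this is the same kind of change as the one from compound 1 to compound 2, but not the same: in compound 4 the place sits next to the ring nitrogen as well as next to the ring sulfur, on a ring with 2 nitrogen and 1 sulfur, whereas in compound 2 the ring holds 1 nitrogen and 1 sulfur. The expected step in this assay is a step that the limit leaves unreadable from compound 3 to compound 4, an expectation that rests on compound 1 and compound 2 both sitting at the limit of > 10000 nM in this assay, at which 3 of the 3 values shown sit, with compound 3 at that limit too. Compound 4 is therefore expected to give 15000 nM in this assay, within a range from 4000 nM to 60000 nM, and most likely only a limit again.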

Compound 4, half-maximal inhibitory concentration: > 10000 nM
Compound 4: only a limit was reported; the forecaster's own chance of this, stated with the estimate: 85%; the middle value does not contradict the limit.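

In this assay compound 4 gives > 10000 nM, which is a limit of the assay and not a number. No step can be read from compound 3 to compound 4, or between any other pair here, since every value stands at the same limit: the limit of > 10000 nM in this assay, at which 4 of the 4 values shown sit.

The compounds shown leave open how strongly any of them inhibits the enzyme, and whether thiophen-2-yl in place of furan-2-yl changes that inhibition on either core.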